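Replacing hydroxy on a carbonyl carbon in compound 2

A few compounds are considered here, and "the series" means these few. Any claim that something is new, unique, unknown or untested is made for them only; others in the source may bear on it.

Compound 1 `O=C(O)CCc1cc2ccc(-c3cc(F)cc(OC(F)F)c3)cc2n1S(=O)(=O)c1cccc(C(F)(F)F)c1` gives > 2.41 h (a limit of the assay, not a number)
Compound 2 `O=C(O)CC1Cc2ccc(-c3cc(F)cc(OC(F)F)c3)cc2N1S(=O)(=O)c1cccc(C(F)(F)F)c1` gives 1.88 h
Compound 3 `O=C(O)CC1CN(S(=O)(=O)c2cccc(C(F)(F)F)c2)c2cc(-c3cc(F)cc(OC(F)F)c3)ccc21` gives 0.76 h

In an ADME assay on microsomes from liver (Mus musculus) for metabolic stability, read by LC-MS, using NADPH, with a stated time of 60 min, tested at 1 uM (a lower number here means that the compound disappears faster, a higher number that the compound lasts longer), compound 2 has the higher of the two exact numbers, and compound 3 lies lower by more than the usual scatter. The next compound, compound 4 `O=C(CC1Cc2ccc(-c3cc(F)cc(OC(F)F)c3)cc2N1S(=O)(=O)c1cccc(C(F)(F)F)c1)N1CCS(=O)(=O)CC1`, carries 1,1-dioxothiomorpholin-4-yl in place of hydroxy on a carbonyl carbon. Among the compounds with values here, no measured pair shows this change, so the expectation is uncertain. A small downward move near the edge of the scatter is expected, estimated as a 1.9-fold lower number from compound 2 to compound 4 (0.27 log units; within the scatter) in this assay (a rough guess). The expected half-life of compound 4 is 1 h (range 0.4 h to 2.4 h).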

Compound 4, half-life: 0.0333 h
Estimate against measurement, compound 4: 30-fold (1.48 log units) above, and the stated range ends above it.
By their numbers in this assay, from the lowest: compound 4; then compound 3; then compound 2. At a limit, above all of these: compound 1.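

Putting 1,1-dioxothiomorpholin-4-yl in place of hydroxy on the carbonyl carbon gives a 56-fold lower number from compound 2 to compound 4 (1.75 log units; beyond the scatter) in this assay. Within the data shown here, this is the first measured change at this place, and it shows that half-life here depends strongly on what the carbonyl carbon carries. Nothing measured here accounts for the loss. Going by these compounds, whether it belongs to this ring or to any loss of hydroxy stays open; a small amine such as dimethylamino, or methoxy, at the same place could separate the two. On these data alone, whether the cores of compound 1 and compound 3 respond alike also stays open.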